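Dropping the nitro group from compound 2

This account rests on a few compounds, and the source may have more. Where it says the series, first, only, none or still open, it means among the compounds named here.

Measured so far in an assay on OCI-Ly3 cells for activation of NF-kappa-B inhibitor alpha (Homo sapiens), read by a luciferase reporter; a higher number here means that more compound is needed for the effect, a lower number that less compound is needed:
- Compound 1 `COc1cc(NS(=O)(=O)c2ccc(C)cc2[N+](=O)[O-])c2ncccc2c1` gives 7600 nM in this assay.
- Compound 2 `COc1cc(NS(=O)(=O)c2ccc(C)cc2[N+](=O)[O-])c2nc(C)ccc2c1` gives > 57000 nM in this assay, which is a limit of the assay and not a number.

Compound 2 therefore stands only at a limit, as noted by the limit of > 57000 nM in this assay, at which 1 of the 2 values shown sits, so its true value is not pinned down. Going by the values given here, the single measured step, an at least 7.5-fold higher number from compound 1 to compound 2 (0.87 log units; beyond the scatter), concerns a methyl in place of hydrogen on an aromatic carbon and says nothing about a nitro group.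

Compound 3 `COc1cc(NS(=O)(=O)c2ccc(C)cc2)c2nc(C)ccc2c1` is not yet measured. It differs from compound 2 by hydrogen in place of nitro on an aromatic carbon. Among the compounds with values here, no measured step covers this kind of change, so its direction and size in this assay cannot be read from the data. With compound 2 already at the limit, the likeliest outcome is that compound 3 also reaches only a limit. The expected step that the limit leaves unreadable from compound 2 to compound 3 is accordingly one that the assay probably cannot resolve, with wide uncertainty. Compound 3 is expected near 80000 nM in this assay, within a range from 20000 nM to 300000 nM.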

Compound 3, half-maximal effective concentration: 20000 nM
Compound 3: middle estimate off by 4.0-fold (0.60 log units), on the high side; measured number inside the range.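

In this assay, putting hydrogen in place of the nitro group gives an at least 2.8-fold lower number from compound 2 to compound 3 (0.45 log units; beyond the scatter), which shows that this position, on a six-membered aromatic ring of carbon only, ortho to a large group and meta to a methyl group, responds to change, and that a measurable number in this series does not depend on the nitro group. Compound 2 stands at > 57000 nM, which is a limit of the assay and not a number. The step is therefore only a minimum, and the real gap between the two compounds could be wider than the one printed: the limit of > 57000 nM in this assay, at which 1 of the 3 values shown sits.

The compounds shown hold only nitro or hydrogen at this position, so it stays open whether an amine, a fluorine atom or a carboxylic acid there would lower the number further or raise it again. It also stays open whether the same exchange on compound 1, which carries hydrogen where compound 2 carries its added methyl, would move the number in the same direction, since no pair shown tests this.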